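Four compounds and a limit that holds

This account rests on a few compounds, and the source may have more. Where it says the series, first, only, none or still open, it means among the compounds named here.

Values in an ADME assay on Akata cells (Homo sapiens) for cytotoxicity, with a stated time of 7 days; on this read-out higher numbers stand for lower toxicity in this test and lower numbers for higher toxicity in this test:
- compound 1 `CNc1nc(N)nc2c1ncn2/C=C1/CC1(CO)CO`: > 24000 nM
- compound 2 `Nc1nc(OCC(F)(F)F)c2ncn(/C=C3/CC3(CO)CO)c2n1`: > 20000 nM
- compound 3 `CCCCCCCCOc1nc(N)nc2c1ncn2/C=C1/CC1(CO)CO`: > 20000 nM
- compound 4 `Nc1nc(NCc2ccccc2)c2ncn(/C=C3/CC3(CO)CO)c2n1`: not yet measured

All three measured values are limits and not numbers. Compound 3 stands at the limit of > 20000 nM in this assay, at which 2 of the 3 values shown sit, a position it shares with compound 2. Compound 1 stands at the limit of > 24000 nM in this assay, at which 1 of the 3 values shown sits. None of the three has a number that could be placed in an order.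

The next step replaces the octyloxy of compound 3 with benzylamino on an aromatic carbon, next to the ring nitrogen (benzylamino in place of octyloxy on an aromatic carbon). Among the measured compounds shown here, three measured steps bear on this change: a step that the two limits leave unreadable from compound 1 to compound 2, a step that the two limits leave unreadable from compound 1 to compound 3 and a step that the two limits leave unreadable from compound 2 to compound 3. None of them has a readable size. Still, the same place has carried methylamino, 2,2,2-trifluoroethoxy and octyloxy, and each of those compounds reached only a limit. With no size to carry over, no step beyond the scatter is expected in this assay, and no direction can be named.

The expected change is a step that the limit leaves unreadable from compound 3 to compound 4. Most likely the assay will again report only a limit. For compound 4 the estimated value is 22000 nM, within an expected range from 9000 nM to 50000 nM.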

Compound 4, half-maximal cytotoxic concentration: > 24000 nM
Compound 4 gave a limit, no number; the forecaster's own chance of this, stated with the estimate: 75%; middle value at least 1.0-fold (0.03 log units) from the limit.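

In this assay compound 4 also gave only a limit: the limit of > 24000 nM in this assay, at which 2 of the 4 values shown sit.

Among the compounds shown here, compound 1, compound 2 and compound 3 likewise stand at limits, and no step from any of them to compound 4 can be read. The compounds shown leave open at what concentration any of them turns cytotoxic, and whether methylamino, 2,2,2-trifluoroethoxy, octyloxy and benzylamino differ at all in this assay.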